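The compounds below may be only part of what the source reports. "The series", "measured", "known", "first", "only" and "open" are said of these compounds alone.

Compound 1 `CNC(=O)c1cc(C(=O)NC2CC2)cn(Cc2ccc(OC)cc2)c1=O`: 3
Compound 2 `CNC(=O)c1cc(C(=O)NC(C)C)cn(Cc2ccccc2)c1=O`: 3.6
Compound 3 `CNC(=O)c1cc(C(=O)NC2CCC2)cn(Cc2ccccn2)c1=O`: 2.2

These three compounds share a core and were measured in a physicochemical assay for lipophilicity, at pH 7.4; on this read-out lower numbers stand for lower lipophilicity and higher numbers for higher lipophilicity. Compound 1 stands second highest of the three: compound 2 gives a number higher than compound 1 by more than the scatter, while compound 3 gives a number lower than compound 1 by more than the scatter. Compound 4 `CNC(=O)c1cc(C(=O)NC2CC2)cn(Cc2cccc(OC)c2)c1=O` has the same atoms as compound 1, joined differently (3-methoxyphenyl in place of 4-methoxyphenyl on a saturated chain carbon bound to an aromatic nitrogen). Among the measured compounds no pair differs in only one place, so no measured step can guide this change. Since only the position of the methoxy group on the ring moves, no step beyond the scatter is expected. The expected step of no change at the digits printed from compound 1 to compound 4 (within the scatter) should stay within the scatter. Compound 4 is therefore expected to give 3, with a range from 2.6 to 3.4.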

Compound 4, distribution coefficient: 3
Compound 4: the middle estimate sits on the measured number at the digits printed; the range from low to high includes it.
By their numbers in this assay, from the lowest: compound 3; then compounds 1 and 4 (each within the scatter of the next); then compound 2.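

Moving the methoxy group gives no change at the digits printed from compound 1 to compound 4 (within the scatter) in this assay and offers the first comparison here between two compounds that differ in one place. On a saturated chain carbon bound to an aromatic nitrogen, 3-methoxyphenyl and 4-methoxyphenyl therefore cannot be told apart by this read-out. No measurement shown accounts for this result. Still open, going by these compounds, is whether a phenyl ring carrying an amine or a carboxylic acid in place of the methoxy group would stay this close to compound 1. On these data alone, whether the same swap gives a similar result with other amides on the shared core also remains open.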